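The compounds below may be only part of what the source reports. "The series", "measured", "known", "first", "only" and "open" are said of these compounds alone.

Measured compounds in the series:

- compound 1, `CNC(=O)Nc1ccc(-c2nc(N3CC4CCC(C3)O4)c3sccc3n2)cc1`: 85 nM
- compound 2, `COC(=O)Nc1ccc(-c2nc(N3CC4CCC(C3)O4)c3sccc3n2)cc1`: 1850 nM
- compound 3, `CS(=O)(=O)N1CCN(Cc2cc3nc(-c4ccc(NC(=O)NC5CC5)cc4)nc(N4CC5CCC(C4)O5)c3s2)CC1`: 32 nM

In a functional assay on LNCaP cells (Homo sapiens) for cytotoxicity (a higher number here means a weaker inhibitor, a lower number a stronger inhibitor), compound 3 gives the lowest number of the three; its value and that of compound 1 lie beyond the scatter of each other, and compound 2 lies far above both. For the measured compounds named here, the only one-place step recorded, a 22-fold higher number from compound 1 to compound 2 (1.34 log units; beyond the scatter), concerns the carbonyl substituent and does not touch the part of the molecule that changes here.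

Compound 4, `O=C(Nc1ccc(-c2nc(N3CC4CCC(C3)O4)c3sccc3n2)cc1)NC1CC1`, is not yet measured. It differs from compound 3 by hydrogen in place of (4-(methylsulfonyl)piperazin-1-yl)methyl on an aromatic carbon. Going by the values given here, no measured pair isolates the loss of this group, so the expectation rests on the observation that compound 1, which also lacks it, sits within a modest distance of compound 3 in this assay. A small to moderate rise in the number is therefore expected, a 2.2-fold higher number from compound 3 to compound 4 (0.34 log units; beyond the scatter), with wide uncertainty. For compound 4 the estimate in this assay is 70 nM, in the range 25 nM to 200 nM.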

Compound 4, half-maximal inhibitory concentration: 40 nM
Compound 4: the middle estimate sits 1.8-fold (0.24 log units) above what was measured; the measured number falls inside the stated range.
By their numbers in this assay, from the lowest: compounds 3 and 4 (each within the scatter of the next); then compound 1; then compound 2.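

In this assay, the step at the aromatic carbon next to the ring sulfur is small: a 1.3-fold higher number from compound 3 to compound 4 (0.10 log units; within the scatter) shows that hydrogen in place of the (4-(methylsulfonyl)piperazin-1-yl)methyl group gives no readable change, so this large group is neither needed nor harmful in this cell read-out. The carbonyl substituent remains the part of the series that moves the number, with a 2.1-fold lower number from compound 1 to compound 4 (0.33 log units; beyond the scatter) for cyclopropyl on the amide-type nitrogen and a 46-fold lower number from compound 2 to compound 4 (1.67 log units; beyond the scatter) for cyclopropylamino in place of methoxy. No supporting measurement accounts for the size of any of these steps.

As far as these compounds go, it remains open whether a free piperazine amine or a carboxylic acid at this ring position would also stay within the scatter. From the compounds shown here alone, how a longer chain such as n-propyl on the amide-type nitrogen would compare with cyclopropyl is also open.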